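From isobutyl to cyclohexyl on the amide nitrogen

The compounds below may be only part of what the source reports. "The series", "measured", "known", "first", "only" and "open" are said of these compounds alone.

Results in a functional assay on the whole organism with Mus musculus as the target; a higher number here means that more compound is needed for the effect, a lower number that less compound is needed:
Compound 1 `CC(C)NC(=O)CCC(=O)c1cccc(C(F)(F)F)c1`: > 200 mg/kg (a limit)
Compound 2 `CC(C)CNC(=O)CCC(=O)c1cccc(C(F)(F)F)c1`: > 200 mg/kg (a limit)

In this assay compound 2 stands at > 200 mg/kg, which is a limit and not a number. Compound 3 `O=C(CCC(=O)c1cccc(C(F)(F)F)c1)NC1CCCCC1` carries cyclohexyl in place of isobutyl on an amide-type nitrogen. Within the data shown here, the only measured step is a step that the two limits leave unreadable from compound 1 to compound 2, and it offers no size to carry over. The evidence amounts to the limit of > 200 mg/kg in this assay, at which 2 of the 2 values shown sit. Among the measured compounds shown here, no step of definite size or direction can therefore be expected. The estimated change is a step that the limit leaves unreadable from compound 2 to compound 3. Compound 3 is expected at 250 mg/kg, with an estimated range from 120 mg/kg to 500 mg/kg.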

Compound 3, dose for half-maximal effect: > 200 mg/kg
Compound 3: no number, only a limit; the forecaster's own chance of this, stated with the estimate: 70%; the middle value is on the limit's open side.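

In this assay, among these compounds, compound 3 also gives only a limit, > 200 mg/kg, so no step from compound 1 or compound 2 to compound 3 can be read. The compounds shown leave open whether any of these groups on the amide nitrogen changes the dose needed, as all the data rest on one limit: the limit of > 200 mg/kg in this assay, at which 3 of the 3 values shown sit.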